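This account rests on a few compounds, and the source may have more. Where it says the series, first, only, none or still open, it means among the compounds named here.

Working notes on the series.

The series is a set of four close analogues around one shared core, tested in an assay for inhibition of protein arginine N-methyltransferase 1 (Rattus norvegicus), read by scintillation counting, with stated times of 15 min and 60 min, in the presence of a further agent that is not named here; on this read-out higher numbers stand for weaker inhibition and lower numbers for stronger inhibition. Compound 1 `CN(C)CCNCc1ccccc1Sc1ccccc1` carries no substituent on the terminal ring and no methyl on the chain nitrogen. In this assay compound 1 reports only the limit > 50000 nM, which is a limit of the measurement and not a number (the limit of > 50000 nM in this assay, at which 1 of the 3 values shown sits). Compound 2 `CN(C)CCNCc1ccccc1Sc1ccccc1F` differs from compound 1 by fluoro in place of hydrogen on an aromatic carbon. In this assay compound 2 gives 45000 nM; the step is an at least 1.1-fold lower number from compound 1 to compound 2 (0.04 log units; that floor lies within the scatter). Compound 3 `CN(C)CCN(C)Cc1ccccc1Sc1ccccc1` differs from compound 1 by methyl in place of hydrogen on an amine nitrogen. In this assay compound 3 gives 3600 nM, and the step is an at least 13-fold lower number from compound 1 to compound 3 (1.14 log units; beyond the scatter). Among the numbers known so far compound 3 stands lowest, with compound 2 next.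

Compound 4 `CN(C)CCN(C)Cc1ccccc1Sc1ccccc1F` has not yet been measured. It differs from compound 3 by fluoro in place of hydrogen on an aromatic carbon. Among the measured compounds shown here, this is the same change as the one from compound 1 to compound 2, since the two place descriptions read alike word for word; that earlier step ran an at least 1.1-fold lower number from compound 1 to compound 2 (0.04 log units; that floor lies within the scatter), a floor that lies within the scatter. The cores of compound 3 and compound 4 are the same, and compound 3 relates to compound 1 by methyl in place of hydrogen on an amine nitrogen.

For the measured compounds named here, on that basis the step from compound 3 to compound 4 in this assay is expected to be small, a 1.2-fold lower number from compound 3 to compound 4 (0.08 log units; within the scatter), because the only measured instance of this change gave an at least 1.1-fold lower number from compound 1 to compound 2 (0.04 log units; that floor lies within the scatter). Compound 4 is therefore expected to give about 3000 nM in this assay, most plausibly between 1200 nM and 9000 nM.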

Compound 4, half-maximal inhibitory concentration: 710 nM
Compound 4: middle estimate off by 4.2-fold (0.63 log units), on the high side, outside the stated range (below it).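

In this assay, fluoro in place of hydrogen on an aromatic carbon, carried onto the core with the methyl on the chain nitrogen, gives a 5.1-fold lower number from compound 3 to compound 4 (0.71 log units; beyond the scatter), and methyl in place of hydrogen on the amine nitrogen, carried onto the core with the 2-fluorophenyl group, gives a 63-fold lower number from compound 2 to compound 4 (1.80 log units; beyond the scatter); on these cores both changes lower the number beyond the scatter. For the fluoro change, the data do not show whether the step keeps its size from one core to the other, and its earlier instance has only a floor within the scatter: the same change on two cores in this assay, an at least 1.1-fold lower number (0.04 log units; that floor lies within the scatter) from compound 1 to compound 2 and a 5.1-fold lower number (0.71 log units; beyond the scatter) from compound 3 to compound 4; the limit leaves it open whether they differ. The methyl change lowers the number beyond the scatter on both cores, but the data do not show whether its size depends on the core: the same change on two cores in this assay, an at least 13-fold lower number (1.14 log units; beyond the scatter) from compound 1 to compound 3 and a 63-fold lower number (1.80 log units; beyond the scatter) from compound 2 to compound 4; the limit leaves it open whether they differ.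

The compounds shown leave open whether the fluoro step holds at other places on the terminal ring, whether chloro or methoxy there would act as fluoro does, and whether ethyl on the chain nitrogen would act as methyl does. From the compounds shown here alone, compound 1 gives > 50000 nM, a limit and not a number, so whether the two changes simply add on the shared core also stays open.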